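Alkenyl substituent on the pyridine of TRPV1 antagonists

The source may hold more compounds than are shown below. What is called first, only, known or untested is meant among the compounds shown, and "the series" means these compounds.

Measured compounds:
compound 1 `CCCCCc1nc(C(F)(F)F)ccc1CNC(=O)C(C)c1ccc(NS(C)(=O)=O)c(F)c1` — 1 nM in an assay on CHO cells for antagonist activity at transient receptor potential cation channel subfamily V member 1 (Homo sapiens), read by FLIPR and calcium flux; a higher number here means a weaker inhibitor, a lower number a stronger inhibitor
compound 2 `CC(C(=O)NCc1ccc(C(F)(F)F)nc1C1CCC(F)(F)CC1)c1ccc(NS(C)(=O)=O)c(F)c1` — 1.5 nM in this assay
compound 3 `CC(C)=Cc1nc(C(F)(F)F)ccc1CNC(=O)C(C)c1ccc(NS(C)(=O)=O)c(F)c1` — 11.5 nM in this assay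

Compound 3 gives the highest number of the three in this assay; its nearest neighbour is compound 2, as a 7.7-fold higher number from compound 2 to compound 3 (0.88 log units; beyond the scatter), and compound 1 lies furthest off, as a 12-fold higher number from compound 1 to compound 3 (1.06 log units; beyond the scatter). Compound 1 and compound 2 sit within the scatter of each other, a 1.5-fold higher number from compound 1 to compound 2 (0.18 log units; within the scatter).

Compound 4 `CC(C(=O)NCc1ccc(C(F)(F)F)nc1/C=C/C1CCCCC1)c1ccc(NS(C)(=O)=O)c(F)c1` differs from compound 3 in one place: 2-cyclohexylethenyl in place of 2-methylprop-1-en-1-yl on an aromatic carbon. For the measured compounds named here, the steps that bear on this are the two that replace a larger group on that aromatic carbon with the 2-methylprop-1-en-1-yl group, a 12-fold higher number from compound 1 to compound 3 (1.06 log units; beyond the scatter) and a 7.7-fold higher number from compound 2 to compound 3 (0.88 log units; beyond the scatter), both beyond the scatter and both losses. On these data alone, compound 4 keeps the double bond of compound 3 but carries the six-membered carbon ring of the entering group, so a step back toward compound 1 and compound 2 in this assay is expected, though a double bond in this position remains untested with a ring attached. The expected step is a 3.8-fold lower number from compound 3 to compound 4 (0.58 log units; beyond the scatter). Compound 4 is estimated at 3 nM in this assay, with a range from 0.8 nM to 12 nM.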

Compound 4, inhibition constant: 0.7 nM
Compound 4: middle estimate off by 4.3-fold (0.63 log units), on the high side; measured number outside the range, below it.
By their numbers in this assay, from the lowest: compounds 4, 1 and 2 (each within the scatter of the next, the first and the last beyond it); then compound 3.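

In this assay the double bond on this aromatic carbon does not by itself carry the loss seen with 2-methylprop-1-en-1-yl: 2-cyclohexylethenyl also has one double bond outside aromatic rings and recovers the full loss and more (a 16-fold lower number from compound 3 to compound 4 (1.22 log units; beyond the scatter)). The alkene with the ring also edges past the saturated ring of 4,4-difluorocyclohexyl (a 2.1-fold lower number from compound 2 to compound 4 (0.33 log units; beyond the scatter)), while it stays within the scatter of the open chain of pentyl (a 1.4-fold lower number from compound 1 to compound 4 (0.15 log units; within the scatter)), so a ring and an open chain both fit at this position among these compounds. Nothing at hand accounts for these differences.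

On these data alone, whether 2-cyclohexylethyl, the same group without the double bond, or the cis isomer of 2-cyclohexylethenyl would hold the number of compound 4 stays open. Also open, as far as these compounds go, is how a phenyl ring or an amine at the end of the two-carbon link would fare.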